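The source may hold more compounds than are shown below. What is called first, only, known or untested is meant among the compounds shown, and "the series" means these compounds.

Of the compounds shown here, three with a shared core have been measured in a functional assay (B cells) with Mus musculus as the target; on this read-out higher numbers stand for an effect only at larger amounts of compound and lower numbers for an effect already at smaller amounts. Compound 1, `Nc1nc(O)c2c(n1)n(C1OC(CO)[C@@H](O)[C@H]1O)c(=O)n2Cc1ccc(Cl)cc1`, gives 14 uM in this assay, the second highest of the three numbers. Compound 3, `C=CCn1c(=O)n(C2OC(CO[Si](c3ccccc3)(c3ccccc3)C(C)(C)C)[C@@H](O)[C@H]2O)c2nc(N)nc(O)c21`, gives 18 uM in this assay, a gap from compound 1 that lies within the scatter. Compound 2, `C=CCn1c(=O)n(Cc2ccccc2)c2nc(N)nc(O)c21`, gives 5 uM in this assay, and this gap from compound 1 lies beyond the scatter. No two of these compounds differ in only one place, so no single step can be read from them.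

Compound 4, `Nc1nc(O)c2c(n1)n(C1OC(CO)[C@@H](O)[C@H]1O)c(=O)n2CC(O)CO`, has not yet been measured. It differs from compound 1 as follows: 1,2-dihydroxyethyl in place of 4-chlorophenyl on a saturated chain carbon bound to an aromatic nitrogen. Both compounds that give the lower numbers, compound 2 and compound 1, carry an aromatic group at this position, while compound 4 carries none. The account therefore expects the step of a 2.5-fold higher number from compound 1 to compound 4 (0.40 log units; beyond the scatter) to run toward a higher number, beyond the scatter. For compound 4 in this assay the estimate is 35 uM, with a range from 12 uM to 100 uM.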

Compound 4, concentration for half-maximal effect: 45 uM
Compound 4: middle estimate off by 1.3-fold (0.11 log units), on the low side; the range from low to high includes it.
By their numbers in this assay, from the lowest: compound 2; then compounds 1 and 3 (each within the scatter of the next); then compound 4.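

In this assay, within the data shown here, the change from 4-chlorobenzyl to 2,3-dihydroxypropyl gives a 3.2-fold higher number from compound 1 to compound 4 (0.51 log units; beyond the scatter) and is the first single change that can be read at this position. It shows that this saturated chain carbon bound to an aromatic nitrogen is not indifferent to what it carries: with the rest of compound 1 held constant, exchanging 4-chlorophenyl for 1,2-dihydroxyethyl moves the read-out beyond the scatter. Nothing available here explains this step.

The chlorine, the aromatic ring and the two hydroxyl groups all change together in this one step, so it remains open which of them accounts for the shift. An unsubstituted benzyl, a plain propyl chain or a chain ending in an amine at this place on the core of compound 1 would help to separate these contributions.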